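Working notes: a trifluoromethyl-to-hydrogen step in the series

The compounds below may be only part of what the source reports. "The series", "measured", "known", "first", "only" and "open" are said of these compounds alone.

Three compounds of this set have been run in a functional assay on HeLa cells (Homo sapiens) for inhibition, read by MTT assay, with a stated time of 72 h; on this read-out higher numbers stand for weaker inhibition and lower numbers for stronger inhibition. Compound 1 `COc1cc(OC)c(OC)cc1/C=C/C(=O)c1cc(Cc2ccccc2)cc(Cc2ccccc2)c1` gives 26900 nM in this assay. Compound 2 `COc1cc(OC)c(OC)cc1/C=C/C(=O)c1cccc(C(F)(F)F)c1` returns only a limit of the assay, > 150000 nM. Compound 3 `COc1cc(OC)c(-c2cc(=O)c3cc(Cl)ccc3o2)cc1OC` likewise returns only a limit, > 150000 nM. Compound 2 therefore stands at the limit (the limit of > 150000 nM in this assay, at which 2 of the 3 values shown sit), and no numbered value is known for it. Compound 4 `COc1cc(OC)c(OC)cc1/C=C/C(=O)c1ccccc1` differs from compound 2 in one place: hydrogen in place of trifluoromethyl on an aromatic carbon. Within the data shown here, no step between measured compounds covers this change, so nothing in the data fixes its size. The step of an at least 1.5-fold lower number from compound 2 to compound 4 (0.17 log units; that floor lies within the scatter) is expected to be small, within the scatter or not far beyond it. Compound 4 is estimated at 100000 nM, with a range from 30000 nM to 150000 nM.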

Compound 4, half-maximal inhibitory concentration: > 150000 nM
Compound 4 gave a limit, no number; the forecaster's own chance of this, stated with the estimate: 45%; middle value at least 1.5-fold (0.17 log units) away from the limit.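

Compound 2 and compound 4 both return only a limit in this assay, so no step can be read for hydrogen in place of trifluoromethyl: the limit of > 150000 nM in this assay, at which 3 of the 4 values shown sit. The compounds shown leave open whether this change alters inhibition at all.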